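The source may hold more compounds than are shown below. What is called first, only, known or untested is meant among the compounds shown, and "the series" means these compounds.

Measured so far in an assay on membranes from HeLa cells for displacement of a labelled ligand from adenosine receptor A3 (Homo sapiens), read by scintillation counting, with a stated time of 180 min, tested at 1 uM; on this read-out lower numbers stand for less inhibition and higher numbers for more inhibition at the one concentration tested (going by the name of the read-out):
compound 1 `CC1=C(C(=O)OC2CCC2)C(c2ccoc2)NC(=O)N1` gives 1%
compound 2 `CC1=C(C(=O)OC2CCCC2)C(c2ccoc2)NC(=O)N1` gives 1%

Compound 2 stands level with compound 1 at the digits shown; the two values sit within the scatter of each other, so no order between them is claimed. Among the compounds with values here, the one measured step, no change at the digits printed from compound 1 to compound 2 (within the scatter), is cyclopentyl in place of cyclobutyl on an oxygen next to a carbonyl group and brought no change beyond the scatter.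

The next compound, compound 3 `CC1=C(C(=O)OC2CCCCC2)C(c2ccoc2)NC(=O)N1`, carries cyclohexyl in place of cyclopentyl on an oxygen next to a carbonyl group. Within the data shown here, this is the same kind of change carried one ring size further on, and the single measured step of that kind is the only one that bears on it. That step was flat, and both measured values are near the bottom of the read-out, so the step from compound 2 to compound 3 is expected to be a number 1 percentage points higher from compound 2 to compound 3 (within the scatter), none beyond the scatter. Compound 3 is therefore estimated at 2%, with a range of -6% to 12%.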

Compound 3, a percentage reported as inhibition, at one concentration (the size of the read-out at that concentration, not a potency): 1%
Beside the measured number, compound 3's estimate is 1 percentage points above it; the range from low to high includes it.
By their numbers in this assay, from the lowest: compounds 1, 2 and 3 (each within the scatter of the next).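

In this assay, cyclohexyl on an oxygen next to a carbonyl group gives a flat step (no change at the digits printed from compound 2 to compound 3 (within the scatter)), and the step taken directly from cyclobutyl is flat as well (no change at the digits printed from compound 1 to compound 3 (within the scatter)). The flat reading at this place therefore now spans three carbon-only rings, from cyclobutyl through cyclopentyl to cyclohexyl, rather than a single pair of neighbouring ring sizes. No evidence is available to explain this flat reading.

The three compounds leave open whether any other group at this place, such as a phenyl ring, a longer chain or a chain ending in an amine, would separate from these rings. They also leave open whether the same rings would still read alike if the rest of the shared core were altered.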